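The source may report more compounds than this note shows. Statements on the series, on what has been measured and on what is new or still open speak of the compounds shown alone.

In an assay on CHO-K1 cells for displacement of a labelled ligand from melanin-concentrating hormone receptor 1 (Homo sapiens), read by scintillation proximity assay, with a stated time of 2 h (on this read-out lower numbers stand for stronger inhibition and higher numbers for weaker inhibition), three compounds have been measured:

Compound 1 `Cc1nc(N2CCC(O)CC2)nc2ccc(NC(=O)/C=C/c3ccc(Cl)cc3)cc12`: 107 nM
Compound 2 `Cc1nc(NCCCNS(C)(=O)=O)nc2ccc(NC(=O)/C=C/c3ccc(OC(F)(F)F)cc3)cc12`: 54 nM
Compound 3 `Cc1nc(N2CCC(O)(C3CC3)CC2)nc2ccc(NC(=O)/C=C/c3ccc(C(F)(F)F)cc3)cc12`: 232 nM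

Compound 2 stands at the lowest of the three numbers; its value and that of compound 1 lie within the scatter of each other, while compound 3 sits beyond the scatter above it. Compound 4 `Cc1nc(N2CCC(N3CCNC3=O)CC2)nc2ccc(NC(=O)/C=C/c3ccc(OC(F)(F)F)cc3)cc12` is not yet measured in this assay. It differs from compound 2 in one place: 4-(2-oxoimidazolidin-1-yl)piperidin-1-yl in place of (3-(methanesulfonamido)propyl)amino on an aromatic carbon. Among the compounds with values here, no pair of measured compounds isolates this change, so the expected step from compound 2 to compound 4 in this assay is uncertain; a modest weakening is expected, a 1.6-fold higher number from compound 2 to compound 4 (0.20 log units; within the scatter), with a wide range. Compound 4 is estimated at 85 nM, between 25 nM and 280 nM.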

Compound 4, half-maximal inhibitory concentration: 66 nM
Beside the measured number, compound 4's estimate is 1.3-fold (0.11 log units) above it; measured number inside the range.
By their numbers in this assay, from the lowest: compounds 2, 4 and 1 (each within the scatter of the next); then compound 3.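

In this assay, replacing (3-(methanesulfonamido)propyl)amino with 4-(2-oxoimidazolidin-1-yl)piperidin-1-yl on the aromatic carbon between two ring nitrogen atoms gives a 1.2-fold higher number from compound 2 to compound 4 (0.09 log units; within the scatter) and so leaves the number unchanged within the scatter. Within the data shown here, this is the first single-place comparison at this position, and it shows that an open chain and a group with two non-aromatic rings can give values within the scatter of each other. Nothing measured here explains this result.

On these data alone, whether a morpholine or a chain ending in a carboxylic acid would fare alike at this position remains open. So does whether the same exchange would give a similar step with a different group on the cinnamide-side phenyl ring.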